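Heteroaryl amide variation in a free fatty acid receptor 2 series

This account rests on a few compounds, and the source may have more. Where it says the series, first, only, none or still open, it means among the compounds named here.

Measured so far:
compound 1, `CC(C)[C@H](C(=O)Nc1ccccn1)c1ccc(Cl)cc1`, 92%
compound 2, `CC(C)[C@H](C(=O)Nc1cccnn1)c1ccc(Cl)cc1`, 101%
compound 3, `CC(C)[C@H](C(=O)Nc1ncc[nH]1)c1ccc(Cl)cc1`, 55%

In a functional assay on CHO cells for agonist activity at Free fatty acid receptor 2 (Homo sapiens), read by cAMP accumulation (on this read-out higher numbers stand for larger maximal responses and lower numbers for smaller maximal responses), compound 1 gives 92% and compound 2 gives 101%; these two are within the scatter of each other, a number 9 percentage points higher from compound 1 to compound 2 (within the scatter). Compound 3 stands lowest of the three numbers: a number 37 percentage points lower from compound 1 to compound 3 (beyond the scatter) and a number 46 percentage points lower from compound 2 to compound 3 (beyond the scatter), both beyond the scatter.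

The next compound is compound 4, `CC(C)[C@H](C(=O)Nc1ccon1)c1ccc(Cl)cc1`. It differs from compound 3 in one place: 1,2-oxazol-3-yl in place of 1H-imidazol-2-yl on an amide-type nitrogen.

Within the data shown here, no measured step carries the 1,2-oxazol-3-yl group, so the bearing steps are those that remove or introduce 1H-imidazol-2-yl: from compound 1 to compound 3 and from compound 2 to compound 3, both large drops. Replacing 1H-imidazol-2-yl is therefore expected to move the maximal response upward, though whether a five-membered ring recovers the full level of compounds 1 and 2 is not shown by any measured pair. The step from compound 3 to compound 4 is estimated at a number 25 percentage points higher from compound 3 to compound 4 (beyond the scatter), upward, beyond the scatter.

For compound 4 the expected value in this assay is 80%, with a range of 55% to 105%.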

Compound 4, largest response reached (reported as efficacy), in percent of the reference or control that the assay uses: 90%
Compound 4: the middle estimate sits 10 percentage points below what was measured, and the stated range covers the measured number.
By their numbers in this assay, from the lowest: compound 3; then compounds 4, 1 and 2 (each within the scatter of the next, the first and the last beyond it).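

In this assay the 1,2-oxazol-3-yl group on the amide-type nitrogen gives a large recovery from the 1H-imidazol-2-yl amide (a number 35 percentage points higher from compound 3 to compound 4 (beyond the scatter)), so a five-membered aromatic ring with 2 hetero atoms at this position is compatible with a high maximal response, and the low value of compound 3 does not follow from ring size alone. Against the six-membered groups, the picture is split: the change from pyridin-2-yl stays within the scatter (a number 2 percentage points lower from compound 1 to compound 4 (within the scatter)), while the change from pyridazin-3-yl is a modest step beyond it (a number 11 percentage points lower from compound 2 to compound 4 (beyond the scatter)), so among the four compounds shown only 1H-imidazol-2-yl stands clearly apart. No supporting data bear on why the response differs between these groups.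

On these data alone, the leaving group carries 1 hydrogen-bond donor and the entering group 0 hydrogen-bond donors, but this pair also changes the ring atoms, so its link to the maximal response stays open; a 1-methyl-1H-imidazol-2-yl amide would separate the two changes. As far as these compounds go, whether the 1,2-oxazol-3-yl result carries over to other five-membered groups, such as 1,3-thiazol-2-yl, also remains open.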